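The source may report more compounds than this note shows. Statements on the series, on what has been measured and on what is new or still open speak of the compounds shown alone.

Compound 1 `O=C(CN1CCN(c2ccccc2)CC1)Nc1nc2ccccc2[nH]1` gives 4.62% in a functional assay, read by spectrophotometry, with a stated time of 30 min, tested at 5 ug/mL; a lower number here means a weaker effect, a higher number a stronger effect of the compound at the concentration tested. Compound 2 `COc1ccc(N2CCN(CC(=O)Nc3nc4ccccc4[nH]3)CC2)cc1` gives 7.24% in this assay.

Among the measured compounds shown here, both numbers are small, and compound 2 sits alongside compound 1 within the usual scatter: the only measured step is a number 2.6 percentage points higher from compound 1 to compound 2 (within the scatter), which adds a methoxy on an aromatic carbon where compound 1 carries hydrogen.

Compound 3 `O=C(CN1CCN(c2ccc([N+](=O)[O-])cc2)CC1)Nc1nc2ccccc2[nH]1` has not yet been measured. It differs from compound 2 by nitro in place of methoxy on an aromatic carbon. For the measured compounds named here, no measured pair exchanges methoxy for nitro, so nothing directly tells what this change does. Going by the values given here, the one step that touches the same aromatic carbon, a number 2.6 percentage points higher from compound 1 to compound 2 (within the scatter), stayed within the scatter, and it is the only guide. On that basis compound 3 is expected to show a number 0.2 percentage points lower from compound 2 to compound 3 (within the scatter), nothing beyond the scatter in either direction. The estimate for compound 3 in this assay is therefore 7%, with a range from 0% to 18%.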

Compound 3, a percentage reported as activity, at one concentration (the size of the read-out at that concentration, not a potency) in the functional assay: 16.1%
Compound 3: the middle estimate sits 9.1 percentage points below what was measured; the measured number falls inside the stated range.
By their numbers in the functional assay, from the lowest: compounds 1, 2 and 3 (each within the scatter of the next, the first and the last beyond it).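

Among the compounds shown here, in the functional assay, nitro in place of hydrogen gives a number 11.5 percentage points higher from compound 1 to compound 3 (beyond the scatter), the first step in this short series to pass the scatter, while nitro in place of methoxy gives a number 8.9 percentage points higher from compound 2 to compound 3 (within the scatter). So the aromatic carbon para to a large group does respond to what sits on it, though only modestly, and compound 3 stands clearly apart from compound 1 alone. In a physicochemical assay for lipophilicity, read by spectrophotometry, using the shake flask method, measured as octanol-water partition, with a stated time of 24 h (a higher number here means a more lipophilic compound, a lower number a more polar compound), compound 2 gives 2.65 and compound 3 gives 1.94. Nitro in place of methoxy also leaves a more polar compound in the physicochemical assay: the measured partition coefficient of compound 2, 2.65, and of compound 3, 1.94, a number 0.71 log units lower (beyond the scatter)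

Going by these compounds, whether this drop in lipophilicity has anything to do with the result in the functional assay stays open, since three compounds cannot separate the two. Also open, on these data alone, is how an amine or a carboxylic acid on this same carbon would compare with nitro.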